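A Fluoro Substituent Added Beside a Cytotoxicity Limit

The source may hold more compounds than are shown below. What is called first, only, known or untested is meant among the compounds shown, and "the series" means these compounds.

Compound 1 `Cc1ccc(C(O)(c2ccc(Cl)cc2)c2cccnc2)cc1` and compound 2 `N#Cc1ccc(C(O)(c2ccc(Cl)cc2)c2cccnc2)cc1` share one core and differ by cyano in place of methyl on an aromatic carbon. In an ADME assay on L6 cells (Rattus norvegicus) for cytotoxicity, read by resazurin assay, with a stated time of 72 h (a higher number here means a weaker inhibitor, a lower number a stronger inhibitor), compound 1 gives 61000 nM. Compound 2 reaches only a limit of the assay, > 100000 nM, and no number. The step of an at least 1.6-fold higher number from compound 1 to compound 2 (0.21 log units; that floor lies within the scatter) stands against (the limit of > 100000 nM in this assay, at which 1 of the 2 values shown sits). Compound 3 `N#Cc1ccc(C(O)(c2ccc(Cl)cc2)c2cccnc2)c(F)c1` carries fluoro in place of hydrogen on an aromatic carbon. Among the compounds with values here, no measured step involves a fluoro substituent, so in this assay no shift beyond the scatter is expected. The expected step is a number no higher from compound 2 to compound 3 (the limit leaves the size open). Compound 3 is therefore estimated at 100000 nM, within 40000 nM to 250000 nM.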

Compound 3, half-maximal inhibitory concentration: > 100000 nM
Compound 3 ended at the assay's limit; the forecaster's own chance of this, stated with the estimate: 70%; the middle value lies on the limit itself.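

Compound 2 and compound 3 both stand at a limit of this assay and not at a number, so no step can be read between them: the limit of > 100000 nM in this assay, at which 2 of the 3 values shown sit. The compounds shown leave open whether fluoro in place of hydrogen shifts the number in this assay at all.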